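This account rests on a few compounds, and the source may have more. Where it says the series, first, only, none or still open, it means among the compounds named here.

This piece follows a small series of closely related compounds tested in an ADME assay on BJ cells (Homo sapiens) for cytotoxicity, read by CellTiter-Glo and resazurin assay, with a stated time of 72 h; on this read-out lower numbers stand for an effect already at smaller amounts and higher numbers for an effect only at larger amounts of compound. Compound 1 `CC(C)COc1cccc(-c2ccc(C(=O)N(Cc3cccc(OCCCCCC(=O)O)c3)C(C)C)cc2)c1` reaches only a limit of this assay, > 26000 nM. Compound 2 `CC(C)N(Cc1cccc(OCCCCCC(=O)O)c1)C(=O)c1ccc(-c2cccc(Cl)c2)cc1` likewise reaches only a limit of this assay, > 21900 nM. Compound 3 `CCOC(=O)CCCCCOc1cccc(CN(C(=O)c2ccc(-c3cccc(OCC(C)C)c3)cc2)C(C)C)c1` also stops at a limit of this assay, > 26000 nM. Every measured value thus sits at the ceiling of the measurement, as the two summaries show: the limit of > 26000 nM in this assay, at which 2 of the 3 values shown sit, and (the limit of > 21900 nM in this assay, at which 1 of the 3 values shown sits). With all three values at limits, the two measured steps, a step that the two limits leave unreadable from compound 1 to compound 2 and a step that the two limits leave unreadable from compound 1 to compound 3, carry no readable size or direction.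

Compound 4 `CCOC(=O)CCCCCOc1cccc(CN(C(=O)c2ccc(-c3cccc(O)c3)cc2)C(C)C)c1` is not yet measured. It differs from compound 3 by one change: hydrogen in place of isobutyl on an oxygen on an aromatic ring. Among the measured compounds shown here, neither measured step touches this part of the molecule, and both are unreadable in any case, so no size of step can be drawn from them. Since every measured compound here shows no effect within the tested range, compound 4 is expected to behave the same way, and the step from compound 3 to compound 4 is estimated as a step that the limit leaves unreadable from compound 3 to compound 4. For compound 4 the estimated value is 30000 nM, with a range from 12000 nM to 100000 nM.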

Compound 4, half-maximal effective concentration: > 26000 nM
Compound 4: only a limit was reported; the forecaster's own chance of this, stated with the estimate: 85%; the middle value does not contradict the limit.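

Compound 4 gives > 26000 nM in this assay, which is a limit. Compound 3 gives > 26000 nM, also a limit, so the step between these two compounds cannot be read. The compounds shown leave open at what concentration, if any, each would harm these cells.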